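Changing the Group on an Aromatic Nitrogen

A few compounds are considered here, and "the series" means these few. Any claim that something is new, unique, unknown or untested is made for them only; others in the source may bear on it.

Compound 1, `O=S(=O)(O)c1cc(O)c(/N=N/c2ccc(O)c3ccc(O)cc23)c2ccccc12`, reaches only the assay limit in an assay on BaF3 cells with thrombopoietin receptor (Homo sapiens) as the target, read by a luciferase reporter (a higher number here means a larger maximal response, a lower number a smaller maximal response), < 5%.
Compound 2, `Cc1[nH]n(C(C)(C)C)c(=O)c1/N=N/c1c(O)cc(S(=O)(=O)O)c2ccccc12`, likewise sits at a limit in this assay, < 5%.
Compound 3, `Cc1ccc(-n2[nH]c(C)c(/N=N/c3c(O)cc(S(=O)(=O)O)c4ccccc34)c2=O)cc1C`, gives 100% in this assay.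

For the measured compounds named here, compound 3 thus holds the only actual number among the three; the other two values are limits, as the limit of < 5% in this assay, at which 2 of the 3 values shown sit, records. Going by the values given here, the single measured step is a number at least 95 percentage points higher from compound 2 to compound 3 (beyond the scatter), a large gain when a 3,4-dimethylphenyl replaces a tert-butyl on the aromatic nitrogen. Compound 4, `Cc1[nH]n(-c2cc(Cl)c(S(=O)(=O)O)cc2Cl)c(=O)c1/N=N/c1c(O)cc(S(=O)(=O)O)c2ccccc12`, changes that same position again: a group of 12 heavy atoms (6 carbon, 3 oxygen, 1 sulfur, 2 chlorine; one six-membered aromatic ring of carbon only) in place of a group of 8 heavy atoms (8 carbon; one six-membered aromatic ring of carbon only), on an aromatic nitrogen. The measured step shows that the group on this nitrogen governs the response, yet it does not tell how one six-membered aromatic ring of carbon only compares with another, so compound 4 is expected to lose part of the response, estimated as a number 50 percentage points lower from compound 3 to compound 4 (beyond the scatter). For compound 4 the expected value is 50%, within a range of 5% to 100%.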

Compound 4, largest response reached (reported as efficacy), in percent of the reference or control that the assay uses: < 5%
Compound 4: no number, only a limit; the forecaster's own chance of this, stated with the estimate: 30%; middle value at least 45 percentage points from the limit.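

The change on the aromatic nitrogen gives a number at least 95 percentage points lower from compound 3 to compound 4 (beyond the scatter), when the group of 12 heavy atoms replaces the 3,4-dimethylphenyl. A six-membered aromatic ring of carbon only on this nitrogen therefore does not by itself carry the response in this assay; what that ring bears matters as well. The step between compound 2 and compound 4 cannot be read because both sit at a limit: the limit of < 5% in this assay, at which 3 of the 4 values shown sit.

The compounds shown do not separate the effect of the chlorine atoms from that of the sulfur-bearing part. On these data alone, how a ring bearing only chlorine, or a carboxylic acid, would behave on this nitrogen stays open.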